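Side-chain exchange from compound 3 to compound 4

The compounds below may be only part of what the source reports. "The series", "measured", "known", "first", "only" and "open" are said of these compounds alone.

In a functional assay on DU-145 cells (Homo sapiens) for cytotoxicity, read by MTT assay (a higher number here means a weaker inhibitor, a lower number a stronger inhibitor), compound 3 (`CCCCC(O)CC(=O)O[C@H](CC=C(C)C)C1=CC(=O)c2c(O)ccc(O)c2C1=O`) gives 45300 nM and stands level with compound 1 (`CC(C)=CC[C@@H](OC[C@H](C)O)C1=CC(=O)c2c(O)ccc(O)c2C1=O`), which gives 24500 nM as its value. Compound 2 (`CCCC(O)CC(=O)O[C@H](CC=C(C)C)C1=CC(=O)c2c(O)ccc(O)c2C1=O`) gives > 100000 nM as its result, and this is a limit of the assay, not a number.

Compound 4 (`CCC(CO[C@H](CC=C(C)C)C1=CC(=O)c2c(O)ccc(O)c2C1=O)OC(C)=O`) carries 2-acetoxybutyl in place of (2-hydroxyhexyl)carbonyl on an oxygen on a saturated carbon. Among the measured compounds shown here, no measured step makes this exact exchange. The closest is the swap of 2-hydroxypropyl for (2-hydroxyhexyl)carbonyl at that oxygen, which gave a 1.8-fold higher number from compound 1 to compound 3 (0.27 log units; within the scatter) and stayed within the scatter. Two steps go against a flat picture: (2-hydroxypentyl)carbonyl gave an at least 4.0-fold higher number from compound 1 to compound 2 (0.61 log units; beyond the scatter) and one added methyl then gave an at least 2.2-fold lower number from compound 2 to compound 3 (0.34 log units; beyond the scatter), both beyond the scatter and both resting on a limit. Small changes in this group can therefore move the number in either direction, which calls for a wide range.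

With compound 3 and compound 1 level, no step beyond the scatter is expected in this assay. The expected step is a 1.3-fold lower number from compound 3 to compound 4 (0.11 log units; within the scatter) and it carries no firm direction. The estimate for compound 4 is 35000 nM, with an expected range from 11000 nM to 95000 nM.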

Compound 4, half-maximal inhibitory concentration: 25400 nM
For compound 4 the middle estimate is 1.4-fold (0.14 log units) above the measured one, within the range that was stated.
By their numbers in this assay, from the lowest: compounds 1, 4 and 3 (each within the scatter of the next). At a limit, above all of these: compound 2.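

In this assay, 2-acetoxybutyl on an oxygen on a saturated carbon has 0 hydrogen-bond donors against 1 for (2-hydroxyhexyl)carbonyl, yet the exchange gives no readable change, with a 1.8-fold lower number from compound 3 to compound 4 (0.25 log units; within the scatter). Read against the shorter hydroxy side chain, 1-acetoxypropyl in place of 1-hydroxyethyl on a saturated chain carbon bound to an oxygen on a saturated carbon also leaves the result level, with a 1.0-fold higher number from compound 1 to compound 4 (0.02 log units; within the scatter), so compounds 1, 3 and 4 now form a level group carrying three different side chains at this oxygen. The only new step beyond the scatter is an at least 3.9-fold lower number from compound 2 to compound 4 (0.59 log units; beyond the scatter), and it rests on compound 2, whose value is a limit of the assay and not a number: the limit of > 100000 nM in this assay, at which 1 of the 4 values shown sits.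

No pair shown differs only in a free hydroxyl against its acetate, so the contribution of that single change to the level result remains unresolved. On these data alone, how an amine, a carboxylic acid or a longer chain on this oxygen would read in this assay stays open, as does whether any such group would separate from compounds 1, 3 and 4 beyond the scatter.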